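The source may report more compounds than this note shows. Statements on the series, on what has been measured and on what is new or still open speak of the compounds shown alone.

Working notes on the series. Compound 1 `CNc1ncc(C#Cc2cccc(C)c2)cn1` carries a methylamino group on the shared core; in an assay on HEK293 cells for positive allosteric modulation of metabotropic glutamate receptor 5 (Rattus norvegicus) (on this read-out higher numbers stand for an effect only at larger amounts of compound and lower numbers for an effect already at smaller amounts), compound 1 gives 21100 nM. Compound 2 `CCc1ncc(C#Cc2cccc(C)c2)cn1`, the ethyl analogue, in this assay gives "not active" (no number reported), so no number stands for compound 2 and its place against compound 1 cannot be fixed on the numbers shown. Compound 3 `Cc1cccc(C#Cc2cnc(C)nc2)c1` differs from compound 2 by hydrogen in place of methyl on a saturated chain carbon bound to an aromatic carbon. Going by the values given here, no measured step of this kind exists here; in this assay a shift from compound 2 of no more than the usual scatter is expected, most likely again without a number. Compound 3 is estimated at 40000 nM, within 10000 nM to 150000 nM.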

Compound 3, half-maximal effective concentration: "not active" (no number reported)
Compound 3 has no reported number here, so the estimate cannot be set against anything.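

Compound 2 and compound 3 both carry no reported number, so no step can be read between them, and no available evidence bears on this result. The compounds shown leave open what ethyl to methyl does to a numerical value in this assay.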